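Widening the acyl group on a shared core

The source may hold more compounds than are shown below. What is called first, only, known or untested is meant among the compounds shown, and "the series" means these compounds.

Compound 1 `COc1ccc(N)c(C2=NN(C(C)=O)CC2)c1`: 20.4%
Compound 2 `CCCC(=O)N1CCC(c2cc(OC)ccc2N)=N1`: 13.1%
Compound 3 `COc1ccc(N)c(C2=NN(C(=O)C3CCC3)CC2)c1`: 1.91%

In an assay on isolated protein for inhibition of Nitric oxide synthase, inducible (Homo sapiens), with a stated time of 30 min, tested at 1 mM (a lower number here means less inhibition, a higher number more inhibition at the concentration tested (going by the name of the read-out)), compound 3 stands lowest of the three, with compound 2 nearest at 13.1% and compound 1 furthest at 20.4%. Compound 4 `COc1ccc(N)c(C2=NN(C(=O)C3CCCCC3)CC2)c1` differs from compound 3 by cyclohexyl in place of cyclobutyl on a carbonyl carbon. Within the data shown here, two measured steps bear on this change: a number 18.5 percentage points lower from compound 1 to compound 3 (beyond the scatter) and a number 11.2 percentage points lower from compound 2 to compound 3 (beyond the scatter), both modest drops as the group on the carbonyl carbon grew. A further growth to cyclohexyl is therefore expected to give at most a small drop or no change beyond the scatter, the step of a number 1.9 percentage points lower from compound 3 to compound 4 (within the scatter) being the estimate. For compound 4 the expected value in this assay is 0%, within a range from -8% to 8%.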

Compound 4, a percentage reported as inhibition, at one concentration (the size of the read-out at that concentration, not a potency): 13.3%
Beside the measured number, compound 4's estimate is 13.3 percentage points below it; measured number above the stated range.
By their numbers in this assay, from the lowest: compound 3; then compounds 2, 4 and 1 (each within the scatter of the next).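

In this assay, the fall seen as the group on the carbonyl carbon grew does not continue: cyclohexyl in place of cyclobutyl gives (a number 11.4 percentage points higher from compound 3 to compound 4 (beyond the scatter)). Compound 4 stays within the scatter of the smaller open-chain acyl compounds (a number 0.2 percentage points higher from compound 2 to compound 4 (within the scatter); a number 7.1 percentage points lower from compound 1 to compound 4 (within the scatter)), so compound 3 alone stands apart, and group size alone does not order these numbers. Nothing available here explains why the cyclobutyl compound stands apart.

On these data alone, it remains open whether cyclopentyl, or cyclohexyl carrying an amine, would fall with compound 3 or with compound 4.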